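Removing the Ester Linker Before the Selenocyanate

The source may report more compounds than this note shows. Statements on the series, on what has been measured and on what is new or still open speak of the compounds shown alone.

Three measured compounds share one core and differ in how the selenocyanate is attached. Compound 1 `Cc1nc(N(C)c2ccc([Se]C#N)c(Cl)c2)c2ccccc2n1` carries it on the aromatic ring, and in a functional assay on MDA-MB-231 cells (Homo sapiens) for inhibition, read by MTT assay, with a stated time of 48 h (a higher number here means a weaker inhibitor, a lower number a stronger inhibitor), compound 1 gives 9 nM. Compound 2 `COc1ccc(N(C)c2nc(C)nc3ccccc23)cc1C(=O)OCCCCC[Se]C#N` holds it at the end of a chain attached through an ester, and in this assay compound 2 gives 851 nM. Compound 3 `COc1ccc(N(C)c2nc(C)nc3ccccc23)cc1C(=O)OCC[Se]C#N` has a shorter chain of the same kind, and in this assay compound 3 gives 1480 nM. Compound 3 therefore stands at the highest number of the three, although its gap to compound 2 is within the scatter, while compound 1 lies far below both.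

Compound 4 `COc1ccc(N(C)c2nc(C)nc3ccccc23)cc1C[Se]C#N` differs from compound 3 as follows: a group of 4 heavy atoms (2 carbon, 1 nitrogen, 1 selenium; no ring) in place of a group of 8 heavy atoms (4 carbon, 1 nitrogen, 2 oxygen, 1 selenium; no ring), on an aromatic carbon. Going by the values given here, the one measured step that bears on this is a 1.7-fold higher number from compound 2 to compound 3 (0.24 log units; within the scatter), which shows that shortening the chain alone changed little. The change to compound 4 goes further, removing the ester altogether and placing the remaining group directly on an aromatic carbon, the arrangement compound 1 shows with 9 nM. On this basis compound 4 is expected to give a lower number, a 3.7-fold lower number from compound 3 to compound 4 (0.57 log units; beyond the scatter), an estimate of 400 nM within a range of 80 nM to 2000 nM.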

Compound 4, half-maximal inhibitory concentration: 153 nM
Compound 4: the middle estimate sits 2.6-fold (0.42 log units) above what was measured, within the range that was stated.
By their numbers in this assay, from the lowest: compound 1; then compound 4; then compounds 2 and 3 (each within the scatter of the next).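

In this assay, replacing the ester-bearing group on this aromatic carbon, ortho to a methoxy group, with the smaller group gives a 9.7-fold lower number from compound 3 to compound 4 (0.99 log units; beyond the scatter) and so moves the number by more than the scatter. Shortening the chain while keeping the ester did not do this, as a 1.7-fold higher number from compound 2 to compound 3 (0.24 log units; within the scatter) shows, so among these three compounds only the change that removes the ester and most of the chain gives a step beyond the scatter. The change also takes the carbonyl double bond away and lowers the count of hydrogen-bond acceptors from 3 to 1, but no measurement shown ties the step to either of these or to any other cause.

On these data alone, the step removes the ester and shortens the link to the selenocyanate in a single change, so the share of each stays open; an amide in place of the ester, or a longer chain joined to the ring through carbon alone, would separate the two. Also open, as far as these compounds go, is whether the methoxy group contributes at this position, a question that a compound with chlorine or hydrogen in its place could address.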